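Swapping a Butyl for a Fluorobenzyl Arm

This account rests on a few compounds, and the source may have more. Where it says the series, first, only, none or still open, it means among the compounds named here.

Four close relatives of one sugar-bearing scaffold are compared here. Compound 1 `CCCCN1C(=O)C(O)(CC(=O)C[C@@H]2O[C@H](COC(C)=O)[C@@H](OC(C)=O)[C@H](OC(C)=O)[C@H]2OC(C)=O)c2ccccc21` and compound 2 `CC(=O)OC[C@H]1O[C@@H](CC(=O)CC2(O)C(=O)N(Cc3ccccc3)c3ccccc32)[C@H](OC(C)=O)[C@@H](OC(C)=O)[C@@H]1OC(C)=O` carry a hydroxyl on the central ring carbon, while compound 3 `CCCCN1C(=O)/C(=C\C(=O)C[C@@H]2O[C@H](COC(C)=O)[C@@H](OC(C)=O)[C@H](OC(C)=O)[C@H]2OC(C)=O)c2ccccc21` and compound 4 `CC(=O)OC[C@H]1O[C@@H](CC(=O)/C=C2\C(=O)N(Cc3ccc(F)cc3)c3ccccc32)[C@H](OC(C)=O)[C@@H](OC(C)=O)[C@@H]1OC(C)=O` have that carbon joined to the side chain through a double bond. In an ADME assay on Vero cells (Chlorocebus sabaeus) for cytotoxicity, read by resazurin assay, with a stated time of 72 h (on this read-out higher numbers stand for lower toxicity in this test and lower numbers for higher toxicity in this test), compound 1 gives "not determined" (no result reported), and compound 2 gives "not determined" (no result reported), so neither contributes a number. For the measured compounds named here, compound 3 is therefore the only compound with a result: in this assay compound 3 gives 126000 nM, which is the sole figure available and so serves as the only anchor for what follows.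

Compound 4 differs from compound 3 in one spot: 4-fluorophenyl in place of propyl on a saturated chain carbon bound to an amide-type nitrogen in a ring. Read one bond further out, a butyl becomes a 4-fluorobenzyl on the ring nitrogen. Going by the values given here, the two other relatives give no comparable pair. Among the compounds with values here, there is no measured step to lean on, and the estimate rests on compound 3 alone. The expectation is a step from compound 3 to compound 4 of a 1.4-fold lower number from compound 3 to compound 4 (0.15 log units; within the scatter), that is, no change beyond the usual scatter, with a slight lean toward higher toxicity. Compound 4 is estimated at 90000 nM, within a range from 35000 nM to 250000 nM.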

Compound 4, half-maximal cytotoxic concentration: 119000 nM
The estimate for compound 4 lay 1.3-fold (0.12 log units) below the measured number; the range from low to high includes it.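

In this assay, putting 4-fluorophenyl in place of propyl on a saturated chain carbon bound to an amide-type nitrogen in a ring gives a 1.1-fold lower number from compound 3 to compound 4 (0.02 log units; within the scatter). For the compounds shown here, this is the first comparison the series allows, since a single number could not show whether the group at this place has any bearing on the read-out. Within this one pair, a short open chain and a longer arm carrying an aromatic ring and a fluorine cannot be told apart in this test, although the swap adds a ring and noticeably more atoms; nothing measured here offers an explanation for that.

Steps involving compound 1 and compound 2 cannot be read, so this series does not show how the form with a hydroxyl on the central ring carbon compares with the double-bonded form, or how a benzyl without fluorine compares with the 4-fluorobenzyl. Going by these compounds alone, it also remains open whether a group of a different kind in the same place, such as an amine or a carboxylic acid, would leave the read-out just as undisturbed, since butyl and 4-fluorobenzyl are the only two arms with numbers.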